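This account rests on a few compounds, and the source may have more. Where it says the series, first, only, none or still open, it means among the compounds named here.

Going by the values given here, in a functional assay on Ehrlich cells (Mus musculus) for cytotoxicity, read by LDH release, with a stated time of 48 h (a lower number here means a stronger inhibitor, a higher number a weaker inhibitor), compound 1 `Cc1ccc(OCC(=O)NNC(=O)c2cc3ccccc3oc2=O)c(C(=O)c2ccccc2)c1` gives 81100 nM and compound 2 `Cc1ccc(OCC(=O)NNC(=O)c2cc3ccccc3oc2=O)c(C(=O)c2ccc(F)cc2)c1` gives 40800 nM, so compound 2 stands within the scatter of the only other measured compound. Compound 3 `Cc1ccc(C(=O)c2cc(C)ccc2OCC(=O)NNC(=O)c2cc3ccccc3oc2=O)cc1` differs from compound 2 by methyl in place of fluoro on an aromatic carbon, with methyl in place of fluoro on an aromatic carbon. Among the compounds with values here, the one measured step bearing on this change is a 2.0-fold lower number from compound 1 to compound 2 (0.30 log units; within the scatter), fluoro in place of hydrogen on an aromatic carbon, and it lies within the scatter. No shift beyond the scatter is therefore expected, in either direction. The estimated step is a 1.2-fold higher number from compound 2 to compound 3 (0.09 log units; within the scatter). The expected value for compound 3 is 50000 nM, with an estimated range of 22000 nM to 110000 nM.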

Compound 3, half-maximal inhibitory concentration: 81400 nM
For compound 3 the middle estimate is 1.6-fold (0.21 log units) below the measured one, and the stated range covers the measured number.
By their numbers in this assay, from the lowest: compounds 2, 1 and 3 (each within the scatter of the next).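

In this assay the methyl group gives a second reading at this place, para to a large group: a 2.0-fold higher number from compound 2 to compound 3 (0.30 log units; within the scatter) against fluoro and a 1.0-fold higher number from compound 1 to compound 3 (0.00 log units; within the scatter) against hydrogen, both within the scatter. Hydrogen, fluoro and methyl on this aromatic carbon therefore cannot be told apart by these numbers, and methyl adds no separation that fluoro did not. No supporting data bear on this result.

From the compounds shown here alone, whether an amine, a carboxylic acid or a longer chain at this place would move the number beyond the scatter remains open. Also open, going by these compounds, is whether changes elsewhere on the shared core would do so.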